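A few compounds are considered here, and "the series" means these few. Any claim that something is new, unique, unknown or untested is made for them only; others in the source may bear on it.

For the measured compounds named here, compound 2 `COc1ccc(CCCCOc2ccc(CSCc3cccc(C(=O)O)c3)nc2/C=C/C(=O)O)cc1` is one of only two compounds measured so far in an assay on isolated protein for displacement of a labelled ligand from leukotriene B4 receptor 1 (Homo sapiens); a lower number here means a stronger inhibitor, a higher number a weaker inhibitor. In this assay compound 2 gives 9.2 nM. The other measured compound, compound 1 `COc1ccc(CCCCCCCCOc2ccc(CSCc3cccc(C(=O)O)c3)nc2CCC(=O)O)cc1`, gives 8 nM in this assay. These two numbers lie within the scatter of each other, so neither compound can be called the stronger binder; compound 2 simply has the higher of the two numbers by a margin that means nothing.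

Compound 3 `COc1ccc(CCCCOc2ccc(CSCc3cccc(C(=O)O)c3)nc2CCC(=O)O)cc1` has not yet been measured. It differs from compound 2 in one place: 2-carboxyethyl in place of 2-carboxyethenyl on an aromatic carbon. No measured pair isolates this one change, so the expected size of the step rests only on the numbers already shown. Going by the values given here, compound 1 also carries a 2-carboxyethyl group and gives 8 nM, a number that sits right beside the one for compound 2. On that basis the step from compound 2 to compound 3 is expected to be small, a 1.1-fold higher number from compound 2 to compound 3 (0.04 log units; within the scatter), with no direction that stands out from the scatter. Compound 3 is therefore estimated at 10 nM in this assay, within a range from 3 nM to 35 nM.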

Compound 3, inhibition constant: 28 nM
The estimate for compound 3 lay 2.8-fold (0.45 log units) below the measured number; the range from low to high includes it.
By their numbers in this assay, from the lowest: compounds 1 and 2 (each within the scatter of the next); then compound 3.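

In this assay, 2-carboxyethyl in place of 2-carboxyethenyl on this aromatic carbon, next to the ring nitrogen, gives a 3.0-fold higher number from compound 2 to compound 3 (0.48 log units; beyond the scatter). For the compounds shown here, the two groups differ only in a double bond outside aromatic rings, so this is the first direct sign that the measured binding responds to that single difference at this position, even though the step is modest. The number for compound 1 could not show this on its own: with 2-carboxyethyl held in place, 4-methoxyphenyl in place of 4-(4-methoxyphenyl)butyl on the chain gives a 3.5-fold higher number from compound 1 to compound 3 (0.54 log units; beyond the scatter), so the chain also matters when this group is present. No other measurement here helps to explain either step.

The compounds shown leave open whether these two steps would add up or behave differently in a compound combining 2-carboxyethenyl with the longer chain. On these data alone, it also remains open how a carboxymethyl group or a primary amide on this same aromatic carbon would compare with the two groups tested.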